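The compounds below may be only part of what the source reports. "The series", "measured", "known", "first", "only" and "open" are said of these compounds alone.

The compounds here share one core and differ only in the group on the outer aromatic ring. Compound 1 `Cc1cc(NC(=O)Nc2ccccc2OC(F)(F)F)c2ccccc2n1` carries trifluoromethoxy. In an ADME assay on BJ cells (Homo sapiens) for cytotoxicity, with a stated time of 72 h (a lower number here means that less compound is needed, a higher number that more compound is needed for the effect), compound 1 gives > 25000 nM, which is a limit of the assay rather than a number. Compound 1 thus stands at the limit of > 25000 nM in this assay, at which 1 of the 3 values shown sits. Compound 2 `COC(=O)c1cccc(NC(=O)Nc2cc(C)nc3ccccc23)c1` gives 21000 nM in this assay, and compound 3 `Cc1cc(NC(=O)Nc2ccc(OC(F)(F)F)cc2)c2ccccc2n1` gives 25000 nM; all three values sit close to the top of what the assay measures. Compound 4 `Cc1cc(NC(=O)Nc2ccccc2F)c2ccccc2n1` has not yet been tested; it differs from compound 1 as follows: fluoro in place of trifluoromethoxy on an aromatic carbon. Among the compounds with values here, no step between measured compounds is available, so the neighbouring values alone guide the expectation. Compound 4 is expected to give about 25000 nM, within 10000 nM to 60000 nM. The expected step of a number no higher from compound 1 to compound 4 (the limit leaves the size open) is therefore no larger than the usual scatter.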

Compound 4, half-maximal effective concentration: > 25000 nM
Compound 4 was reported as a limit; the forecaster's own chance of this, stated with the estimate: 60%; the middle value lies on the limit itself.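

Within the data shown here, compound 1 and compound 4 are both reported only as limits of the assay, and no step between them can be read. The compounds shown leave open whether fluoro in place of trifluoromethoxy changes the value in this assay at all.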